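Compound 3 to compound 4: adding trifluoromethyl

The source may hold more compounds than are shown below. What is called first, only, known or untested is meant among the compounds shown, and "the series" means these compounds.

Measured in an ADME assay on BHK-21 cells (Mesocricetus auratus) for cytotoxicity, read by MTT assay; on this read-out lower numbers stand for higher toxicity in this test and higher numbers for lower toxicity in this test:
- compound 1 `C/C(=N\NC(N)=O)c1ccc2[nH]c(-c3ccc(C(F)(F)F)cc3)nc2c1`: > 100000 nM (a limit)
- compound 2 `CC(=O)c1ccc2c(c1)nc(-c1ccc(C(F)(F)F)cc1)n2C1CCCCC1`: 33000 nM
- compound 3 `C/C(=N\NC(N)=O)c1ccc2c(c1)nc(-c1ccccc1)n2C1CCCCC1`: > 100000 nM (a limit)

Compound 3 stands at the limit of > 100000 nM in this assay, at which 2 of the 3 values shown sit, so its position is a limit and not a number. The change to compound 4 `C/C(=N\NC(N)=O)c1ccc2c(c1)nc(-c1ccc(C(F)(F)F)cc1)n2C1CCCCC1` from compound 3 is trifluoromethyl in place of hydrogen on an aromatic carbon, with trifluoromethyl in place of hydrogen on an aromatic carbon, para to a large group, which turns phenyl to 4-(trifluoromethyl)phenyl. Within the data shown here, no measured pair isolates this change. Among the measured compounds shown here, compound 2 carries the same 4-(trifluoromethyl)phenyl group and gives 33000 nM as the only number in the set. Compound 1 also carries that group and goes against any trend, with > 100000 nM as its limit. A modest move toward lower numbers in this assay is therefore expected, possibly no larger than the scatter, and the assay may again report only a limit. The expected change is an at least 1.6-fold lower number from compound 3 to compound 4 (0.22 log units; that floor lies within the scatter) as a tentative estimate. For compound 4 the estimated value is 60000 nM and the expected range runs from 25000 nM to 150000 nM for now.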

Compound 4, half-maximal cytotoxic concentration: > 100000 nM
Compound 4: no number, only a limit (the forecaster's own chance of this, stated with the estimate: 45%); middle value at least 1.6-fold (0.22 log units) from the limit.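

In this assay, among these compounds, the one readable new step is an at least 3.0-fold higher number from compound 2 to compound 4 (0.48 log units; beyond the scatter), and compound 2 and compound 4 differ only in the group on the aromatic carbon of the shared core. The 4-(trifluoromethyl)phenyl and cyclohexyl groups therefore do not bring the number of compound 2 with them once that group is changed. The result for compound 4 is a limit, and its steps from compound 3 and compound 1 cannot be read because each has a limit at both ends: the limit of > 100000 nM in this assay, at which 3 of the 4 values shown sit.

From the compounds shown here alone, how far compound 1, compound 3 and compound 4 lie past that limit remains open, so the size of any trifluoromethyl effect in this setting is unknown. Also open, going by these compounds, is whether an amine or a carboxylic acid in place of trifluoromethyl would give a number rather than a limit in this assay.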